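From pyrrolidin-1-yl to a larger two-ring aromatic group

The source may hold more compounds than are shown below. What is called first, only, known or untested is meant among the compounds shown, and "the series" means these compounds.

Compound 1 `CCCC(=O)c1ccc(NCc2cncn2Cc2ccc(-c3ccccc3)cc2)cc1-c1ccccc1`: > 10000 nM (a limit)
Compound 2 `c1ccc(-c2ccc(Cn3cncc3CNc3ccc(N4CCCC4)c(-c4ccccc4)c3)cc2)cc1`: > 1000 nM (a limit)

In a toxicity assay on NIH3T3 cells (Mus musculus) for cytotoxicity, read by resazurin assay (on this read-out lower numbers stand for an effect already at smaller amounts and higher numbers for an effect only at larger amounts of compound), compound 2 stands at > 1000 nM, which is a limit and not a number. Compound 3 `c1ccc(-c2ccc(Cn3cncc3CNc3ccc(-c4noc5ccccc45)c(-c4ccccc4)c3)cc2)cc1` differs from it at one place on an aromatic carbon: a group of 9 heavy atoms (7 carbon, 1 nitrogen, 1 oxygen; one five-membered aromatic ring with 2 hetero atoms, one six-membered aromatic ring of carbon only) in place of a group of 5 heavy atoms (4 carbon, 1 nitrogen; one five-membered non-aromatic ring with 1 hetero atom), on an aromatic carbon. Among the compounds with values here, the only measured step is a step that the two limits leave unreadable from compound 1 to compound 2. It offers no size or direction to carry over, so a reading of similar kind is expected in this assay, quite possibly another limit. The estimated step, a step that the limit leaves unreadable from compound 2 to compound 3, is only a rough expectation. Compound 3 is expected at 6000 nM, with an estimated range of 1500 nM to 30000 nM.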

Compound 3, half-maximal effective concentration: > 10000 nM
Compound 3 was reported as a limit; the forecaster's own chance of this, stated with the estimate: 70%; middle value at least 1.6-fold (0.22 log units) from the limit.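

In this assay, within the data shown here, compound 1, compound 2 and compound 3 are all reported only as limits, and no step between them can be read. The compounds shown leave open at what concentration any of them would show an effect in this assay.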